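The source may hold more compounds than are shown below. What is called first, only, known or untested is meant among the compounds shown, and "the series" means these compounds.

Measured so far in a functional assay on PANC-1 cells (Homo sapiens) for inhibition, read by MTT assay, with a stated time of 24 h, tested at 10 uM; on this read-out lower numbers stand for less inhibition and higher numbers for more inhibition at the one concentration tested (going by the name of the read-out):
compound 1 `COc1ccc(C(=O)NCCCOc2cc(=O)n(CCCO)c3c2CC(CC=C(C)C)C(C)(C)C3)cc1` gives 2.5%
compound 2 `COc1ccc(OCCCOc2cc(=O)n(CCCO)c3c2CC(CC=C(C)C)C(C)(C)C3)cc1` gives 4.1%

Among the measured compounds shown here, compound 2 and compound 1 lie within the scatter of each other; the only measured step, a number 1.6 percentage points higher from compound 1 to compound 2 (within the scatter), shows no more than that the two read-outs are alike at the tested concentration. Compound 3 `CC(C)=CCC1Cc2c(OCCCOc3ccc([N+](=O)[O-])cc3)cc(=O)n(CCCO)c2CC1(C)C` is not yet measured. It differs from compound 2 in one place: nitro in place of methoxy on an aromatic carbon. The measured step from compound 1 to compound 2 touches the far end of the chain, not the aromatic carbon where the present change sits, so it bears on the new step only loosely: it shows that one exchange at the chain terminus left the read-out where it was. For the measured compounds named here, no measured step exchanges a substituent on that aromatic ring. Going by the values given here, the expectation for compound 3 therefore rests on the read-out of compound 2 being low and on the series so far showing no movement beyond the scatter: the step of a number 0.9 percentage points higher from compound 2 to compound 3 (within the scatter) is expected to stay within the scatter. Compound 3 is estimated at 5%, with a range from 0% to 20%.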

Compound 3, a percentage reported as inhibition, at one concentration (the size of the read-out at that concentration, not a potency): 0%
For compound 3 the middle estimate is 5 percentage points above the measured one; the measured number falls inside the stated range.
By their numbers in this assay, from the lowest: compounds 3, 1 and 2 (each within the scatter of the next).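

In this assay, among the compounds shown here, the first exchange on the aromatic ring at the chain end, nitro in place of methoxy on an aromatic carbon para to a large group, gives a number 4.1 percentage points lower from compound 2 to compound 3 (within the scatter), so the read-out at this position does not separate these two groups. Exchanging the whole chain terminus, with 4-nitrophenoxy in place of ((4-methoxyphenyl)carbonyl)amino, gives a number 2.5 percentage points lower from compound 1 to compound 3 (within the scatter), which leaves all three compounds within the scatter of one another, and compound 3 reads 0%; across this small set, neither the ring substituent nor the linkage at the chain end has yet moved the read-out beyond the scatter. No supporting data are available to explain this flat result.

On these data alone, whether an amine or a carboxylic acid on this aromatic carbon, or a longer chain in place of the present one, would lift the read-out clear of the scatter remains open. With a single tested concentration behind each read-out, any differences among these compounds at other concentrations also remain open.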